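The source may hold more compounds than are shown below. What is called first, only, known or untested is meant among the compounds shown, and "the series" means these compounds.

Measured compounds:
compound 1 `CCN(CC)CCn1c2ccc3ccccc3c2c2nc3ccccc3nc21` gives 180000 nM in an ADME assay on L929 cells (Mus musculus) for cytotoxicity; on this read-out higher numbers stand for lower toxicity in this test and lower numbers for higher toxicity in this test;
compound 2 `CC1CCCCN1CCn1c2ccc3ccccc3c2c2nc3ccccc3nc21` gives 113000 nM in this assay.

Compound 1 and compound 2 share the same core and differ only in the amine at the end of the chain. Within the data shown here, the step of a 1.6-fold lower number from compound 1 to compound 2 (0.20 log units; within the scatter) is within the scatter, so the two compounds cannot be told apart on these numbers; compound 2 simply has the nearer of two indistinguishable values, with compound 1 as its only comparison.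

Compound 3 `CN1CCN(CCn2c3ccc4ccccc4c3c3nc4ccccc4nc32)CC1` is not yet measured. It differs from compound 2 by 4-methylpiperazin-1-yl in place of 2-methylpiperidin-1-yl on a saturated chain carbon, two bonds along the chain from an aromatic nitrogen. Among the measured compounds shown here, the only measured step that bears on this change is the amine swap from compound 1 to compound 2, which stayed within the scatter. Two data points give no ground for expecting a larger effect from a second amine swap at the same place. Compound 3 is therefore expected to give about 130000 nM, with a range of 50000 nM to 320000 nM, and the expected step of a 1.2-fold higher number from compound 2 to compound 3 (0.06 log units; within the scatter) is not beyond the scatter.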

Compound 3, half-maximal cytotoxic concentration: 21400 nM
Compound 3: the middle estimate sits 6.1-fold (0.78 log units) above what was measured; measured number outside the range, below it.
By their numbers in this assay, from the lowest: compound 3; then compounds 2 and 1 (each within the scatter of the next).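

In this assay, the amine at the end of the chain turns out to matter: 4-methylpiperazin-1-yl in place of 2-methylpiperidin-1-yl gives a 5.3-fold lower number from compound 2 to compound 3 (0.72 log units; beyond the scatter), and in place of diethylamino it gives an 8.4-fold lower number from compound 1 to compound 3 (0.92 log units; beyond the scatter), whereas the earlier amine swap stayed within the scatter. So a change on this saturated chain carbon, two bonds along the chain from an aromatic nitrogen, can shift the cytotoxicity read-out beyond the scatter, toward higher toxicity in this test, even when the entering and leaving rings are both six-membered and the same size in heavy atoms, with one ring carrying a second nitrogen. Nothing available explains why this swap moves the number.

The compounds shown leave open whether the shift follows the second ring nitrogen or the different placing of the methyl group, since both change together from compound 2 to compound 3. A 4-methylpiperidin-1-yl group, a morpholine or an unsubstituted piperazine at the end of the same chain would help separate these two changes, and a longer chain would test whether the link itself matters.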